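The compounds below may be only part of what the source reports. "The series", "measured", "known", "first", "only" and "open" are said of these compounds alone.

Compound 2 `COc1ccccc1/C=C/c1ccccc1O` and compound 3 `COc1ccc(/C=C/c2ccccc2O)cc1` have the same atoms joined differently; the difference between the two cores is not broken down here. In a functional assay on MCF7 cells (Homo sapiens) for inhibition, read by MTT assay, with a stated time of 2 days (a higher number here means a weaker inhibitor, a lower number a stronger inhibitor), compound 2 gives 17.9 ug/mL, and compound 3 gives 17 ug/mL; these two numbers lie within the usual scatter of each other. Compound 1 `Nc1ccccc1/C=C/c1ccccc1O` differs from compound 2 by amino in place of methoxy on an aromatic carbon. In this assay compound 1 gives 39 ug/mL, a step that is a 2.2-fold higher number from compound 2 to compound 1 (0.34 log units; beyond the scatter). Compound 4 `Nc1ccc(/C=C/c2ccccc2O)cc1` has not yet been measured; it differs from compound 3 by amino in place of methoxy on an aromatic carbon. This is the same kind of change as that seen between compound 2 and compound 1, though the place is not identical: in the measured pair the amino sits ortho to a group of 9 heavy atoms, whereas in compound 4 it sits para to such a group. In this assay the expected step is a 2.0-fold higher number from compound 3 to compound 4 (0.30 log units; within the scatter), an expectation that rests on a 2.2-fold higher number from compound 2 to compound 1 (0.34 log units; beyond the scatter) and on compound 2 and compound 3 giving numbers within the scatter of each other. Compound 4 is therefore estimated to give 34 ug/mL in this assay, with a likely range from 17 ug/mL to 68 ug/mL.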

Compound 4, half-maximal inhibitory concentration: 23 ug/mL
The estimate for compound 4 lay 1.5-fold (0.17 log units) above the measured number; the range from low to high includes it.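

In this assay, amino in place of methoxy on an aromatic carbon gives a 1.4-fold higher number from compound 3 to compound 4 (0.13 log units; within the scatter) and so does not clearly separate these two compounds. Set beside the earlier step on the other core, this step does not differ from it by more than two such steps can be expected to scatter: the same change on two cores in this assay, a 2.2-fold higher number (0.34 log units; beyond the scatter) from compound 2 to compound 1 and a 1.4-fold higher number (0.13 log units; within the scatter) from compound 3 to compound 4, 1.6-fold (0.21 log units) apart, within the scatter of two such steps. Going by these compounds alone, this shows that the change can be carried between these two cores with a step of compatible size, but it does not show that the effect is the same on both, since only one pair per core is available and only the earlier step lies beyond the scatter.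

The compounds shown carry only methoxy and amino at these places, so what a carboxylic acid, a nitrile or a longer chain would give there remains open. As far as these compounds go, it also remains open whether the step would hold on any further core or in any other cell line.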